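The source may hold more compounds than are shown below. What is called first, only, known or untested is meant among the compounds shown, and "the series" means these compounds.

Series notes, values in an ADME assay on Vero cells (Chlorocebus sabaeus) for inhibition, read by MTT assay, with a stated time of 72 h (on this read-out higher numbers stand for weaker inhibition and lower numbers for stronger inhibition), each one a limit of the assay:

- compound 1 `O=C(O)CCCCCCC(=O)Nc1ccc(C2=C(c3ccc(O)cc3)C3CC(S(=O)(=O)Oc4ccccc4C(F)(F)F)C2O3)cc1` gives > 100000 nM
- compound 2 `O=C(CCCCCCC(=O)Nc1ccc(C2=C(c3ccc(O)cc3)C3CC(S(=O)(=O)Oc4ccccc4)C2O3)cc1)NO` gives > 100000 nM
- compound 3 `Cc1ccccc1OS(=O)(=O)C1CC2OC1C(c1ccc(NC(=O)CCCCCCC(=O)O)cc1)=C2c1ccc(O)cc1` gives > 100000 nM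

Compound 3 stands at > 100000 nM, which is a limit and not a number. The same holds across the set, with the limit of > 100000 nM in this assay, at which 3 of the 3 values shown sit.

The next compound is compound 4 `O=C(O)CCCCCCC(=O)Nc1ccc(C2=C(c3ccc(O)cc3)C3CC(S(=O)(=O)Oc4ccc(C(F)(F)F)cc4)C2O3)cc1`, not yet measured, which carries 4-(trifluoromethyl)phenyl in place of 2-methylphenyl on an oxygen whose other neighbour is the sulfonyl sulfur: 4-(trifluoromethyl)phenyl in place of 2-methylphenyl on an oxygen.

For the measured compounds named here, the one measured step that bears on this change is a step that the two limits leave unreadable from compound 1 to compound 3, so compound 1 and compound 3 supply no size to carry over. With every measured compound at the same limit, nothing points to activity appearing in this assay, and compound 4 is expected to report only a limit as well. The step expected is a number no higher from compound 3 to compound 4 (the limit leaves the size open), with none expected beyond the scatter. For compound 4 the estimated value is 100000 nM, with an expected range of 40000 nM to 200000 nM.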

Compound 4, half-maximal inhibitory concentration: > 100000 nM
Compound 4 gave a limit, no number; the forecaster's own chance of this, stated with the estimate: 85%; the middle value lies on the limit itself.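

No new step can be read: compound 4, like compound 1 and compound 3, reports only a limit of the assay, and the steps joining these limits have no readable size. The compounds shown leave open whether any of them differs from another, as all sit at one limit: the limit of > 100000 nM in this assay, at which 4 of the 4 values shown sit.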